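The compounds below may be only part of what the source reports. "The series", "measured", "known", "first", "only" and "open" are said of these compounds alone.

Measured so far in a functional assay on HT-29 cells (Homo sapiens) for antiproliferative activity, read by MTT assay, with a stated time of 72 h; on this read-out lower numbers stand for stronger inhibition and higher numbers for weaker inhibition:

compound 1 `CNc1nc(-c2cc(OC)c(OC)c(OC)c2)c(-c2ccc(C)cc2)s1` gives 423 nM
compound 2 `CNc1nc(-c2cc(OC)c(OC)c(OC)c2)c(-c2ccc(C(F)(F)F)cc2)s1` gives 1240 nM
compound 3 `COc1cc(-c2nc(N(C)C)sc2-c2ccc(C)cc2)cc(OC)c1OC` gives 3920 nM

Compound 4 `COc1cc(-c2nc(N(C)C)sc2-c2ccc(C(F)(F)F)cc2)cc(OC)c1OC` has not yet been measured in this assay.

Compound 3 gives the highest number of the three, and its steps to both other compounds lie beyond the scatter. The core of compound 3 differs from the core of compound 1 by methyl in place of hydrogen on a nitrogen on an aromatic ring; in this assay that difference gave a 9.3-fold higher number from compound 1 to compound 3 (0.97 log units; beyond the scatter).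

On the core of compound 1 the change to compound 2 is trifluoromethyl in place of methyl on an aromatic carbon, and it gave a 2.9-fold higher number from compound 1 to compound 2 (0.47 log units; beyond the scatter). The change from compound 3 to compound 4 is trifluoromethyl in place of methyl on an aromatic carbon. Its place reads the same word for word as the place of the change from compound 1 to compound 2, so it is the same change, made once on each core; among the compounds shown it occurs twice in all.

Within the data shown here, only one measured instance of this change exists, so the expectation for compound 4 rests on that single step and on the value of compound 3 as the starting point. A step of roughly the same size is expected, a 2.6-fold higher number from compound 3 to compound 4 (0.41 log units; beyond the scatter), with the caveat that a single earlier instance gives no indication of how the step varies between cores.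

Compound 4 is therefore expected to give about 10000 nM in this assay, estimated to fall between 4500 nM and 25000 nM.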

Compound 4, half-maximal inhibitory concentration: > 10000 nM
Compound 4 ended at the assay's limit (the forecaster's own chance of this, stated with the estimate: 20%); the middle value sits exactly at the limit.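

In this assay compound 4 gives > 10000 nM, which is a limit of the assay and not a number: the limit of > 10000 nM in this assay, at which 1 of the 4 values shown sits. Trifluoromethyl in place of methyl on the aromatic carbon now shows an at least 2.5-fold higher number from compound 3 to compound 4 (0.40 log units; beyond the scatter), so the direction seen on the core of compound 1 carries over to the core of compound 3, while the size of the step on this second core stays unresolved: the same change on two cores in this assay, a 2.9-fold higher number (0.47 log units; beyond the scatter) from compound 1 to compound 2 and an at least 2.5-fold higher number (0.40 log units; beyond the scatter) from compound 3 to compound 4; the limit leaves it open whether they differ. Read the other way round the square, methyl in place of hydrogen on the nitrogen shows an at least 8.0-fold higher number from compound 2 to compound 4 (0.90 log units; beyond the scatter), the same direction as on the 4-methylphenyl compounds, so the two changes go the same way in all four compounds, but neither a constant step nor an interaction between them can be established, and the pattern rests on these four compounds alone: the same change on two cores in this assay, a 9.3-fold higher number (0.97 log units; beyond the scatter) from compound 1 to compound 3 and an at least 8.0-fold higher number (0.90 log units; beyond the scatter) from compound 2 to compound 4; the limit leaves it open whether they differ.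

The compounds shown leave open how other groups at the place of the methyl, such as a chlorine, a methoxy or a nitrile, would compare with methyl and trifluoromethyl. On the nitrogen, they also leave open how a free amine or a longer chain such as ethyl would compare with the methylamino and dimethylamino compounds.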